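Isopropyl in Place of Methyl: What Compound 4 Should Show

The source may report more compounds than this note shows. Statements on the series, on what has been measured and on what is new or still open speak of the compounds shown alone.

Among the compounds with values here, compound 3 `Cc1cc(NC(=O)c2ccc(C)c(Nc3nc(-c4cccnc4)cs3)c2)cc(-n2cnc(C)c2)c1` gives 3290 nM in a functional assay on K562 cells (Homo sapiens) for antiproliferative activity (a higher number here means a weaker inhibitor, a lower number a stronger inhibitor), the highest of the three numbers measured so far. Compound 1 `Cc1cn(-c2cc(NC(=O)c3ccc(C)c(Nc4nc(-c5cccnc5)cs4)c3)cc(C(F)(F)F)c2)cn1` gives 1830 nM, and compound 2 `Cc1ncn(-c2cc(NC(=O)c3ccc(C)c(Nc4nc(-c5cccnc5)cs4)c3)cc(C(F)(F)F)c2)n1` gives 1630 nM. The step of a 1.8-fold higher number from compound 1 to compound 3 (0.25 log units; within the scatter) lies within the scatter, whereas the gap between compound 3 and compound 2 lies beyond it. Compound 4 `Cc1cn(-c2cc(NC(=O)c3ccc(C)c(Nc4nc(-c5cccnc5)cs4)c3)cc(C(C)C)c2)cn1` differs from compound 3 by isopropyl in place of methyl on an aromatic carbon. Within the data shown here, no measured step exchanges methyl for isopropyl. Among the measured compounds shown here, the only step at that position, a 1.8-fold higher number from compound 1 to compound 3 (0.25 log units; within the scatter), stayed within the scatter, and a 1.1-fold lower number from compound 1 to compound 2 (0.05 log units; within the scatter) elsewhere was likewise small. Compound 4 is therefore expected to show no step beyond the scatter, a 1.1-fold lower number from compound 3 to compound 4 (0.04 log units; within the scatter), with an estimated 3000 nM and a range from 1200 nM to 8000 nM.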

Compound 4, half-maximal inhibitory concentration: 2910 nM
Compound 4: the middle estimate sits 1.0-fold (0.01 log units) above what was measured, and the stated range covers the measured number.
By their numbers in this assay, from the lowest: compounds 2, 1, 4 and 3 (each within the scatter of the next, the first and the last beyond it).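

In this assay the aromatic carbon now carries a third group, and neither a 1.1-fold lower number from compound 3 to compound 4 (0.05 log units; within the scatter) nor a 1.6-fold higher number from compound 1 to compound 4 (0.20 log units; within the scatter) goes beyond the scatter. The earlier compounds shown here had only methyl and trifluoromethyl here, so isopropyl, with its 3 heavy atoms, shows that a larger carbon group in this place leaves the number within the scatter of both. Nothing measured here explains why these steps stay so small. The compounds shown leave open whether an amine, a carboxylic acid or a longer chain at this position would give a step beyond the scatter.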